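This account rests on a few compounds, and the source may have more. Where it says the series, first, only, none or still open, it means among the compounds named here.

Working notes on the series. Compound 3 `NC(=O)c1ccc(-c2cnc(C(=O)CCCCCCc3ccccc3)o2)cc1` gives 10 nM in an assay (Rattus norvegicus) for inhibition of Fatty-acid amide hydrolase 1 (Homo sapiens) (a lower number here means a stronger inhibitor, a higher number a weaker inhibitor), the lowest of the three numbers; compound 1 `O=C(CCCCCCc1ccccc1)c1ncc(-c2cccc(O)c2)o1` gives 50 nM and compound 2 `COc1ccc(-c2cnc(C(=O)CCCCCCc3ccccc3)o2)cc1` gives 100 nM. The steps of a 5.0-fold lower number from compound 1 to compound 3 (0.70 log units; beyond the scatter) and a 10-fold lower number from compound 2 to compound 3 (1.00 log units; beyond the scatter) both favour the 4-carbamoylphenyl, whereas a 2.0-fold higher number from compound 1 to compound 2 (0.30 log units; within the scatter) lies within the scatter. Compound 4 `O=C(CCCCCCc1ccccc1)c1ncc(-c2ccncn2)o1` carries the change (pyrimidin-4-yl in place of 4-carbamoylphenyl on an aromatic carbon). Among the compounds with values here, the carbamoyl that sets compound 3 apart is gone, and no measured compound bears a pyrimidin-4-yl, so the comparison is indirect. Given the two steps into compound 3, a higher number is expected for compound 4, of roughly the size of those steps, though with wide uncertainty. Compound 4 is estimated at 60 nM, with a range of 20 nM to 200 nM, meaning an expected step of a 6.0-fold higher number from compound 3 to compound 4 (0.78 log units; beyond the scatter).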

Compound 4, inhibition constant: 2.3 nM
Estimate against measurement, compound 4: 26-fold (1.42 log units) above; measured number below the stated range.
By their numbers in this assay, from the lowest: compound 4; then compound 3; then compounds 1 and 2 (each within the scatter of the next).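

The aromatic carbon next to the ring oxygen needs neither the carbamoyl nor a ring of carbon only for a low number, since the pyrimidin-4-yl, with no hydrogen-bond donor, goes lower still (a 4.3-fold lower number from compound 3 to compound 4 (0.64 log units; beyond the scatter)). The gaps to the other two compounds are large (a 22-fold lower number from compound 1 to compound 4 (1.34 log units; beyond the scatter); a 43-fold lower number from compound 2 to compound 4 (1.64 log units; beyond the scatter)), leaving compound 4 lowest of the four. No evidence at hand bears on this result.

On these data alone, whether both ring nitrogens matter remains open, and a pyridin-2-yl or pyridin-4-yl here would test that. Also open, as far as these compounds go, is whether the gain persists with a shorter chain on the carbonyl.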